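From 2-Oxopiperidin-1-yl to 2-(Methylsulfonyl)phenyl Against Trypsin

The compounds below may be only part of what the source reports. "The series", "measured", "known", "first", "only" and "open" are said of these compounds alone.

Of the compounds shown here, three built on a shared core have been measured in an assay on isolated protein for inhibition of Trypsin (Homo sapiens) (a lower number here means a stronger inhibitor, a higher number a weaker inhibitor), and every one of them returned only a limit of the assay rather than a number. Compound 1 `COc1ccc(-n2nc(C(F)(F)F)cc2C(=O)Cc2ccc(-c3ccccc3S(N)(=O)=O)cc2)cc1` gives a limit, > 2500 nM. Compound 2 `CC(C(=O)c1cc(C(F)(F)F)nn1-c1ccc2onc(N)c2c1)c1ccc(-c2ccccc2S(C)(=O)=O)cc1` likewise gives only a limit, > 20000 nM. Compound 3 `Nc1noc2ccc(-n3nc(C(F)(F)F)cc3C(=O)Cc3ccc(N4CCCCC4=O)cc3)cc12` also gives only a limit, > 20000 nM. Among the measured compounds shown here, compound 3 therefore stands together with compound 2 at the limit of > 20000 nM in this assay, at which 2 of the 3 values shown sit, while compound 1 rests at the limit of > 2500 nM in this assay, at which 1 of the 3 values shown sits; no measured number separates any pair, so no step between the measured compounds can be sized.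

The step that follows leads from compound 3 to compound 4 `CS(=O)(=O)c1ccccc1-c1ccc(CC(=O)c2cc(C(F)(F)F)nn2-c2ccc3onc(N)c3c2)cc1`. 2-(methylsulfonyl)phenyl in place of 2-oxopiperidin-1-yl on an aromatic carbon Compound 4 shares the 2-(methylsulfonyl)phenyl group with compound 2, and in this assay compound 2 gave only a limit, > 20000 nM.

For the measured compounds named here, with no measured step in this assay to lean on, the expectation is for no change beyond the scatter, and the expected step is a step that the limit leaves unreadable from compound 3 to compound 4. Compound 4 is estimated at 30000 nM, within a range from 8000 nM to 150000 nM, and it is expected most likely to return only a limit as well.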

Compound 4, inhibition constant: > 20000 nM
Compound 4 gave a limit, no number; the forecaster's own chance of this, stated with the estimate: 85%; the middle value does not contradict the limit.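

In this assay compound 4 returned only a limit, > 20000 nM. Among the compounds shown here, compound 2 and compound 3 also rest on limits, so no step to compound 4 can be read from either. The compounds shown leave open whether 2-(methylsulfonyl)phenyl in place of 2-oxopiperidin-1-yl, or hydrogen in place of methyl, changes the result in this assay at all.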